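Amine-linked sulfonyl-lactam series: single-concentration inhibition

This account rests on a few compounds, and the source may have more. Where it says the series, first, only, none or still open, it means among the compounds named here.

Measured so far:
compound 1, `CCN(CCCn1sc2cc(OC)c(OC)cc2c1=O)Cc1ccc(N(C)C)cc1`, 40.1%
compound 2, `CCN(CCCCCCN1C(=O)c2cc(OC)c(OC)cc2S1(=O)=O)Cc1ccccc1`, 38.9%

In an assay on isolated protein for inhibition of Amine oxidase [flavin-containing] B (Homo sapiens), read by fluorescence, with a stated time of 30 min, tested at 10 uM (on this read-out lower numbers stand for less inhibition and higher numbers for more inhibition at the one concentration tested (going by the name of the read-out)), compound 2 gives 38.9%, the lower of two numbers; compound 1 gives 40.1%, which lies within the scatter of compound 2, so the two show no difference. Compound 3, `COc1ccccc1CN(C)CCCCCCN1C(=O)c2cc(OC)c(OC)cc2S1(=O)=O`, differs from compound 2 in one place: (2-methoxybenzyl)(methyl)amino in place of benzyl(ethyl)amino on a saturated chain carbon, six bonds along the chain from an amide-type nitrogen in a ring. Within the data shown here, no step between measured compounds is available, and the two values give no direction. The step of a number 0.9 percentage points lower from compound 2 to compound 3 (within the scatter) is expected to stay within the scatter. For compound 3 in this assay the estimate is 38%, range 20% to 55%.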

Compound 3, a percentage reported as inhibition, at one concentration (the size of the read-out at that concentration, not a potency): 29.2%
Estimate against measurement, compound 3: 8.8 percentage points above, and the stated range covers the measured number.
By their numbers in this assay, from the lowest: compounds 3, 2 and 1 (each within the scatter of the next, the first and the last beyond it).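

In this assay, (2-methoxybenzyl)(methyl)amino in place of benzyl(ethyl)amino gives a number 9.7 percentage points lower from compound 2 to compound 3 (within the scatter) and stays within the scatter, so this first step at the chain end shows no difference between the two amines. The number in this assay therefore stays level across this change, which adds a methoxy group to the benzyl ring and replaces ethyl with methyl on the amine nitrogen. Nothing available explains the size of the step.

From the compounds shown here alone, the separate contributions of methoxy and methyl remain open, since both change together. Benzyl(methyl)amino would separate them, and a piperidine at this place would test a cyclic amine.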